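Chloro in place of methyl: solubility expected for compound 3

A few compounds are considered here, and "the series" means these few. Any claim that something is new, unique, unknown or untested is made for them only; others in the source may bear on it.

Of the compounds shown here, two have been measured for a physicochemical assay for solubility, read by HPLC, measured as kinetic solubility, with a stated time of 24 h, at pH 6.5; a higher number here means a more soluble compound, a lower number a less soluble compound. Compound 1 `Cc1cc(CNC(C)(C)C)c(O)c(Nc2nc3cc(F)c(F)cc3n2Cc2ccc(C(F)(F)F)cc2)c1` carries a methyl group on the ring that also bears the hydroxy group and the ((tert-butyl)amino)methyl group. In this assay compound 1 returns only a limit, < 5000 nM, so no number is known for it. Compound 2 `CCNCc1cc(Cl)cc(Nc2nc3cc(F)c(F)cc3[nH]2)c1O` shares the diflurobenzimidazole-type core only in part, lacking the trifluoromethyl-benzyl substituent and carrying an ethylamino chain instead; in this assay compound 2 gives 12000 nM. For the measured compounds named here, the two compounds differ in more than one place, so their values show only that compound 2 sits at a measured number where compound 1 sits at the limit (the limit of < 5000 nM in this assay, at which 1 of the 2 values shown sits).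

Compound 3 `CC(C)(C)NCc1cc(Cl)cc(Nc2nc3cc(F)c(F)cc3n2Cc2ccc(C(F)(F)F)cc2)c1O` is the next candidate. It differs from compound 1 in one place: chloro in place of methyl on an aromatic carbon. Going by the values given here, no measured pair tracks this change, so no step in this assay can be read from the data. Because compound 1 already sits at the limit of < 5000 nM in this assay, at which 1 of the 2 values shown sits, the expected step that the limit leaves unreadable from compound 1 to compound 3 is taken as none beyond the scatter. Compound 3 is therefore estimated at 3000 nM, with a range from 1000 nM to 8000 nM, and a limit read-out is thought likely.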

Compound 3, solubility: < 5000 nM
Compound 3: no number, only a limit; the forecaster's own chance of this, stated with the estimate: 70%; the middle value lies beyond the limit too.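

No step from compound 1 to compound 3 can be read in this assay, since both compounds return only a limit: the limit of < 5000 nM in this assay, at which 2 of the 3 values shown sit.

The compounds shown leave open whether chloro in place of methyl on an aromatic carbon changes this read-out at all, and how compound 1 and compound 3 stand relative to each other.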